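A 3-Hydroxyphenyl Replaces 1-Hydroxycyclohexyl on the Triple Bond

The source may report more compounds than this note shows. Statements on the series, on what has been measured and on what is new or still open speak of the compounds shown alone.

In a functional assay on NIH3T3 cells (Mus musculus) (on this read-out lower numbers stand for an effect already at smaller amounts and higher numbers for an effect only at larger amounts of compound), compound 1 `Cn1cncc1C(OCc1ccc(C#N)cc1C#CC1(O)CCCCC1)c1ccc(C#N)cc1` gives 1.93 nM, the lowest of the three measured numbers. Compound 2 `Cn1cncc1C(OCc1ccc(C#N)cc1/C=C/c1ccccn1)c1ccc(C#N)cc1` gives 23.1 nM and compound 3 `Cn1cncc1C(OCc1ccc(C#N)cc1C#CCCCCO)c1ccc(C#N)cc1` gives 20.9 nM, and the step of a 1.1-fold lower number from compound 2 to compound 3 (0.04 log units; within the scatter) stays within the scatter. Compound 4 `Cn1cncc1C(OCc1ccc(C#N)cc1C#Cc1cccc(O)c1)c1ccc(C#N)cc1` has not yet been measured. It differs from compound 1 by one change: 3-hydroxyphenyl in place of 1-hydroxycyclohexyl on a triple-bonded carbon. For the measured compounds named here, two measured steps bear on this change, an 11-fold higher number from compound 1 to compound 3 (1.03 log units; beyond the scatter) and a 12-fold higher number from compound 1 to compound 2 (1.08 log units; beyond the scatter). Both are large and both remove 1-hydroxycyclohexyl, but neither introduces 3-hydroxyphenyl, which keeps a six-membered ring in that place. A rise somewhat smaller than those steps is therefore expected, with an estimated 4.1-fold higher number from compound 1 to compound 4 (0.62 log units; beyond the scatter). For compound 4, the estimated value in this assay is 8 nM, with an expected range of 2 nM to 35 nM.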

Compound 4, half-maximal effective concentration: > 0.1 nM
Compound 4: only a limit was reported (the forecaster's own chance of this, stated with the estimate: 2%); the middle value does not contradict the limit.
By their numbers in this assay, from the lowest: compound 1; then compounds 3 and 2 (each within the scatter of the next).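

In this assay compound 4 carries only a limit, > 0.1 nM. For the compounds shown here, no step to compound 4 from compound 1, compound 2 or compound 3 can be read. On these data alone, whether 3-hydroxyphenyl in place of 1-hydroxycyclohexyl on a triple-bonded carbon raises or lowers the number stays open.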